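Extending the Alkyne Terminus of a Kinase Inhibitor Core

The source may hold more compounds than are shown below. What is called first, only, known or untested is meant among the compounds shown, and "the series" means these compounds.

Compound 1 `C#Cc1ccc2ncn(-c3ccnc(N)n3)c2c1` — 251 nM
Compound 2 `C=Cc1ccnc(C#Cc2ccc3ncn(-c4ccnc(N)n4)c3c2)c1` — 1580 nM
Compound 3 `C=Cc1ccnc(C#Cc2ccc3ncn(-c4ccnc(N)n4)c3c2)n1` — 1580 nM

In an assay on Sf9 cells for inhibition of mitogen-activated protein kinase kinase kinase 14 variant S549D (Homo sapiens), with a stated time of 30 min, in the presence of a further agent that is not named here (on this read-out higher numbers stand for weaker inhibition and lower numbers for stronger inhibition), compound 1 gives the lowest of the three numbers; compound 2 and compound 3 each stand well above it, and the step of a 6.3-fold higher number from compound 1 to compound 2 (0.80 log units; beyond the scatter) and the step of a 6.3-fold higher number from compound 1 to compound 3 (0.80 log units; beyond the scatter) are both beyond the scatter, while the step of no change at the digits printed from compound 2 to compound 3 (within the scatter) is within it.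

Compound 4 `C=Cc1nccc(C#Cc2ccc3ncn(-c4ccnc(N)n4)c3c2)n1` differs from compound 1 as follows: a group of 8 heavy atoms (6 carbon, 2 nitrogen; one six-membered aromatic ring with 2 hetero atoms) in place of a hydrogen atom, on a triple-bonded carbon. The two steps that bear on this change are those from compound 1 to compound 2 and to compound 3, in which a six-membered aromatic ring was likewise attached to the terminal alkyne carbon, and both gave a modest rise in the number. Since the change to compound 4 is of the same kind, a rise of similar size in this assay is expected, with the step of a 6.0-fold higher number from compound 1 to compound 4 (0.78 log units; beyond the scatter) estimated from compound 1. Compound 4 is therefore expected to give about 1500 nM, within a range from 500 nM to 4500 nM.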

Compound 4, half-maximal inhibitory concentration: 39800 nM
Compound 4: the middle estimate sits 27-fold (1.42 log units) below what was measured; measured number above the stated range.
By their numbers in this assay, from the lowest: compound 1; then compounds 2 and 3 (each within the scatter of the next); then compound 4.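

In this assay the triple-bonded carbon proves far less forgiving than compounds 2 and 3 suggested, with a 160-fold higher number from compound 1 to compound 4 (2.20 log units; beyond the scatter) where their own steps from compound 1 were only modest. The make-up of the attached ring does not settle the outcome: compound 3 carries a ring with the same heavy atoms as compound 4, yet the change is a 25-fold higher number from compound 3 to compound 4 (1.40 log units; beyond the scatter) here. The ring of compound 2, with 1 hetero atom, leaves a gap of the same size, a 25-fold higher number from compound 2 to compound 4 (1.40 log units; beyond the scatter), so the arrangement within the ring, and not the count of hetero atoms alone, separates compound 4 from the other two.

On these data alone, whether an amine or a methoxy group in place of the vinyl group on the ring of compound 4 would restore inhibition remains open. No measurement shown here speaks to the cause of this gap.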